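This account rests on a few compounds, and the source may have more. Where it says the series, first, only, none or still open, it means among the compounds named here.

Compound 1 `COc1cc(F)c(CN2C(=O)N(c3ccc(OC)c(OC)c3)S(=O)(=O)c3ccccc32)c(F)c1`: 0.501 nM
Compound 2 `COc1cc(F)c(CN2C(=O)N(c3cnc(OC)c(OC)c3)S(=O)(=O)c3ccccc32)c(F)c1`: 0.398 nM

In an assay on HEK293 cells for displacement of a labelled ligand from Orexin receptor type 2 (Homo sapiens), read by scintillation counting, with a stated time of 90 min (on this read-out higher numbers stand for weaker inhibition and lower numbers for stronger inhibition), compound 1 gives 0.501 nM and compound 2 gives 0.398 nM; the two numbers lie within the scatter of each other. Compound 3 `COc1ccc(N2C(=O)N(Cc3c(F)cc(C)cc3Cl)c3ccccc3S2(=O)=O)cc1OC` differs from compound 1 by 2-chloro-6-fluoro-4-methylphenyl in place of 2,6-difluoro-4-methoxyphenyl on a saturated chain carbon bound to an amide-type nitrogen in a ring. Within the data shown here, the only measured step, a 1.3-fold lower number from compound 1 to compound 2 (0.10 log units; within the scatter), concerns the other aromatic ring and so gives no guide here. With nothing measured on this part of the molecule, the expected step of a 1.4-fold higher number from compound 1 to compound 3 (0.15 log units; within the scatter) is none beyond the scatter, with a wide range. Compound 3 is therefore estimated at 0.7 nM, between 0.2 nM and 3 nM.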

Compound 3, inhibition constant: 0.794 nM
Estimate against measurement, compound 3: 1.1-fold (0.05 log units) below, within the range that was stated.
By their numbers in this assay, from the lowest: compounds 2, 1 and 3 (each within the scatter of the next).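

Replacing 2,6-difluoro-4-methoxybenzyl with 2-chloro-6-fluoro-4-methylbenzyl, the first change shown at this position, comes with a 1.6-fold higher number from compound 1 to compound 3 (0.20 log units; within the scatter) in this assay. On this saturated chain carbon, then, the ring can carry methyl instead of methoxy and chlorine instead of one fluorine while the number stays within the scatter. No measurement here offers an explanation for this result.

As far as these compounds go, the two swaps arrive together, so what each does alone stays open. So does the effect of an amine or a carboxylic acid on this ring.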